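The source may hold more compounds than are shown below. What is called first, only, known or untested is meant among the compounds shown, and "the series" means these compounds.

Compound 1 `O=C(CCCc1ccccc1)Nc1nc2ccccc2c(=O)s1` — in an assay on CHO cells for displacement of a labelled ligand from adenosine receptor A3 (Homo sapiens), read by scintillation counting, with a stated time of 60 min (a higher number here means a weaker inhibitor, a lower number a stronger inhibitor), compound 1 gives > 1000 nM, which is a limit of the assay and not a number.
Compound 2 `O=C(C/C=C/c1ccccc1)Nc1nc2ccccc2c(=O)s1` — in this assay compound 2 gives 158 nM.
Compound 3 `O=C(CCc1ccccc1)Nc1nc2ccccc2c(=O)s1` — in this assay compound 3 gives 390 nM.

All three share one core joined through an amide to a chain that ends in a phenyl. Compound 2 stands lowest of the two numbers shown, and the nearest measured value, that of compound 3, is a higher number beyond the scatter. For the measured compounds named here, the only step between compounds that differ in one place is an at least 2.5-fold lower number from compound 1 to compound 3 (0.40 log units; beyond the scatter); it concerns the length of the chain and leaves the phenyl untouched.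

Compound 4 `O=C(C/C=C/c1ccc(Cl)c(Cl)c1)Nc1nc2ccccc2c(=O)s1` is not yet measured. It differs from compound 2 by 3,4-dichlorophenyl in place of phenyl on a double-bonded chain carbon bound to a double-bonded chain carbon. Going by the values given here, none of the measured steps changes the phenyl itself, so they give no direct guide to this change. With nothing to point either way, the expectation for the step is a 1.2-fold lower number from compound 2 to compound 4 (0.08 log units; within the scatter), meaning a change within the scatter. The estimate for compound 4 is therefore 130 nM, with a range from 40 nM to 450 nM.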

Compound 4, inhibition constant: > 1000 nM
Compound 4: a limit, no number; the forecaster's own chance of this, stated with the estimate: 5%; middle value at least 7.6-fold (0.88 log units) away from the limit.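

For the compounds shown here, until now the only step between compounds differing in one place concerned the length of the chain, and this result is the first to show that the group at the end of the chain also counts. With 3,4-dichlorophenyl in place of phenyl on a double-bonded chain carbon, this assay gives an at least 6.3-fold higher number from compound 2 to compound 4 (0.80 log units; beyond the scatter). The full size of this step stays unknown, as compound 4 sits at a limit of the assay and not at a number: the limit of > 1000 nM in this assay, at which 2 of the 4 values shown sit.

The compounds shown do not tell whether both chlorines are needed for this loss, so a phenyl carrying a single chlorine, a fluorine or a methoxy group remains an open case. They also leave open whether 3,4-dichlorophenyl would act the same way on the saturated chain of compound 3.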